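A few compounds are considered here, and "the series" means these few. Any claim that something is new, unique, unknown or untested is made for them only; others in the source may bear on it.

Working notes on the series. The shared core carries an amide-linked methylene to a five-membered aromatic ring with three nitrogens, and the group on the aromatic nitrogen of that ring is what varies. Compound 1 `Cc1ccc(-n2cc(CNC(=O)c3cccc4c3cnn4C(C)C)nn2)cc1C` bears 3,4-dimethylphenyl there; compound 2 `CC(C)n1ncc2c(C(=O)NCc3cn(-c4cccc(F)c4)nn3)cccc21` bears 3-fluorophenyl; compound 3 `Cc1ccc(-n2cc(CNC(=O)c3cccc4c3cnn4C(C)C)nn2)cc1` bears 4-methylphenyl.

In a functional assay on HepG2 cells (Homo sapiens) for inhibition, read by MTT assay, with a stated time of 72 h (a higher number here means a weaker inhibitor, a lower number a stronger inhibitor), compound 1 reaches only the limit > 40000 nM. In this assay compound 2 likewise gives only the limit > 40000 nM. For compound 3 this assay again reports only the limit > 40000 nM. The steps a step that the two limits leave unreadable from compound 1 to compound 2, a step that the two limits leave unreadable from compound 1 to compound 3 and a step that the two limits leave unreadable from compound 2 to compound 3 therefore cannot be sized, since (the limit of > 40000 nM in this assay, at which 3 of the 3 values shown sit).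

Compound 4 `CC(C)n1ncc2c(C(=O)NCc3cn(Cc4ccccc4)nn3)cccc21` differs from compound 3 by benzyl in place of 4-methylphenyl on an aromatic nitrogen. Within the data shown here, no measured step bears on this change with a readable size, and every aryl variant so far sits at the limit. Compound 4 is expected to remain at or near that limit, with an estimate of 60000 nM in this assay, between 20000 nM and 200000 nM, so that the step that the limit leaves unreadable from compound 3 to compound 4 is expected to be essentially none beyond the scatter.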

Compound 4, half-maximal inhibitory concentration: 13700 nM
Compound 4: middle estimate off by 4.4-fold (0.64 log units), on the high side; measured number below the stated range.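

Benzyl is the first group at this position to give a readable value in this assay, with an at least 2.9-fold lower number from compound 3 to compound 4 (0.46 log units; beyond the scatter), an at least 2.9-fold lower number from compound 2 to compound 4 (0.46 log units; beyond the scatter) and an at least 2.9-fold lower number from compound 1 to compound 4 (0.46 log units; beyond the scatter). The 4-methylphenyl and benzyl groups hold the same atoms, so the way those atoms are joined at this aromatic nitrogen is enough to separate compound 3 from compound 4. All three steps give only a minimum size, and their true sizes stay open because compound 1, compound 2 and compound 3 all sit at a limit: the limit of > 40000 nM in this assay, at which 3 of the 4 values shown sit.

From the compounds shown here alone, it remains open whether the lower number is confined to benzyl or extends to a longer chain such as 2-phenylethyl, or to a benzyl group carrying fluoro or methyl on its ring. Going by these compounds, how an amine or a carboxylic acid on this nitrogen would read in this assay is also open.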